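A few compounds are considered here, and "the series" means these few. Any claim that something is new, unique, unknown or untested is made for them only; others in the source may bear on it.

Measured in a functional assay on RKOp27 cells (Homo sapiens) for cytotoxicity, read by MTT assay, with a stated time of 3 days; on this read-out higher numbers stand for weaker inhibition and lower numbers for stronger inhibition:

- compound 1 `N#Cc1c(NN)nc(SCc2nc3ccccc3[nH]2)nc1-c1ccccc1` gives 2.55 nM
- compound 2 `CNc1nc(SCc2nc3ccccc3[nH]2)nc(-c2ccccc2)c1C#N` gives 3.7 nM
- compound 3 `N#Cc1c(Nc2nccs2)nc(SCc2nc3ccccc3[nH]2)nc1-c1ccccc1` gives 3.2 nM

Compound 3 (3.2 nM) stands within the scatter of both other compounds, so the three values show no order. Next in the series is compound 4 `N#Cc1c(NC(N)=O)nc(SCc2nc3ccccc3[nH]2)nc1-c1ccccc1`, which has carbamoyl in place of 1,3-thiazol-2-yl on a nitrogen on an aromatic ring. Cut one bond further out, the same difference reads (1,3-thiazol-2-yl)amino to ureido.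

All three measured steps bear on this change, since each exchanges one group on that same nitrogen for another. They are a 1.5-fold higher number from compound 1 to compound 2 (0.16 log units; within the scatter), a 1.3-fold higher number from compound 1 to compound 3 (0.10 log units; within the scatter) and a 1.2-fold lower number from compound 2 to compound 3 (0.06 log units; within the scatter). Amino, methyl and 1,3-thiazol-2-yl on that nitrogen therefore give values that cannot be told apart in this assay. For the measured compounds named here, no measured compound has carbamoyl there, so this group itself is untested and the expectation rests on a flat but small set. No step beyond the scatter is expected, and the estimated change is a 1.1-fold higher number from compound 3 to compound 4 (0.04 log units; within the scatter). For compound 4 the expected value is 3.5 nM, with an estimated range from 1.4 nM to 9 nM.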

Compound 4, half-maximal inhibitory concentration: 2.5 nM
Estimate against measurement, compound 4: 1.4-fold (0.15 log units) above; the measured number falls inside the stated range.
By their numbers in this assay, from the lowest: compounds 4, 1, 3 and 2 (each within the scatter of the next).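

In this assay, carbamoyl on the nitrogen on an aromatic ring stays within the scatter of all three earlier groups (a 1.3-fold lower number from compound 3 to compound 4 (0.11 log units; within the scatter); a 1.5-fold lower number from compound 2 to compound 4 (0.17 log units; within the scatter); a 1.0-fold lower number from compound 1 to compound 4 (0.01 log units; within the scatter)). The flat picture at this position therefore now covers four groups: amino, methyl, 1,3-thiazol-2-yl and carbamoyl, the last being the only one of them with a carbonyl, and exchanging the ring of 1,3-thiazol-2-yl for this smaller open group leaves the value indistinguishable. Nothing available here gives a reason why these four groups cannot be told apart.

From the compounds shown here alone, since every step at this nitrogen so far lies within the scatter, it remains open whether any group there can move the number at all, for instance a longer alkyl chain, a phenyl ring, a carboxylic acid or a tertiary amine. Going by these compounds, it also remains open whether the same tolerance would hold on a change elsewhere on the shared core, such as replacing the nitrile or the phenyl group, and whether it would extend beyond this one cell read-out.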